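A few compounds are considered here, and "the series" means these few. Any claim that something is new, unique, unknown or untested is made for them only; others in the source may bear on it.

Working notes on the series. Going by the values given here, in a functional assay on HepG2 cells (Homo sapiens) for cytotoxicity, read by MTT assay, with a stated time of 72 h (a higher number here means a weaker inhibitor, a lower number a stronger inhibitor), compound 1 `CNC(=O)c1cc(Oc2ccc(C(=O)/C=C/c3ccc(OC)c(OC)c3OC)cc2)ccn1` gives 9810 nM, the only numerical reading so far. Compound 2 `CNC(=O)c1cc(Oc2ccc(C(=O)/C=C/c3ccc(Br)cc3)cc2)ccn1` stands at > 50000 nM, which is a limit of the assay and not a number. Among the compounds with values here, compounds 1 and 2 differ in more than one place, so no measured step isolates a single change.

Compound 3 `CNC(=O)c1cc(Oc2ccc(C(=O)/C=C/c3ccccc3)cc2)ccn1` follows from compound 2 by one change, hydrogen in place of bromo on an aromatic carbon, para to a large group: hydrogen in place of bromo on an aromatic carbon. The same difference reads as 4-bromophenyl to phenyl. Within the data shown here, with no measured step to go on, the expected size rests on thin ground. A moderate move toward stronger inhibition in this assay is expected, an at least 2.0-fold lower number from compound 2 to compound 3 (0.30 log units; that floor lies within the scatter), though a result with no change beyond the scatter would not surprise. Among the measured compounds shown here, the expectation is bounded on the strong side by compound 1 at 9810 nM, the only numerical reading available. Compound 3 is estimated at 25000 nM, with an expected range of 10000 nM to 50000 nM.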

Compound 3, half-maximal inhibitory concentration: 6640 nM
Estimate against measurement, compound 3: 3.8-fold (0.58 log units) above; the measured number lies below the stated range.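

In this assay, going by these compounds alone, hydrogen in place of bromo on an aromatic carbon, para to a large group, gives the first single change that can be read: an at least 7.5-fold lower number from compound 2 to compound 3 (0.87 log units; beyond the scatter). Going from 4-bromophenyl to phenyl changes one heavy atom, and that alone separates a compound with a numerical reading from one without, so this position responds in this assay, at least in this one pair. Compound 2 stands at > 50000 nM, which is a limit of the assay and not a number, so the step gives only a floor and its full size stays unknown: the limit of > 50000 nM in this assay, at which 1 of the 3 values shown sits.

One pair cannot tell whether the difference belongs to bromo in particular or would appear with any other group at this place, and fluoro, chloro, an amine or a carboxylic acid on the same aromatic carbon would separate those readings. From the compounds shown here alone, it also remains open whether the same change would have a step of similar size on a different substitution pattern, since the phenyl and 4-bromophenyl pair is the only one that isolates this position.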